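The compounds below may be only part of what the source reports. "The series", "measured", "known", "first", "only" and "open" are said of these compounds alone.

In a functional assay on NCI-H460 cells (Homo sapiens) for cytotoxicity, read by MTT assay, with a stated time of 72 h (on this read-out lower numbers stand for stronger inhibition and higher numbers for weaker inhibition), compound 2 `COc1cc2c(Oc3ccc(NC(=O)c4cn(-c5ccccc5)nn4)cc3F)ccnc2cc1OCCCN1CCCCC1` gives 210 nM, the lowest of the three numbers shown, though both neighbours sit within the scatter: compound 3 `COc1cc2c(Oc3ccc(NC(=O)c4cn(-c5ccc(F)c(F)c5)nn4)cc3F)ccnc2cc1OCCCN1CCCCC1` gives 250 nM and compound 1 `COc1cc2c(Oc3ccc(NC(=O)c4cn(-c5ccccc5)nn4)cc3F)ccnc2cc1OCCCN1CCCC1` gives 280 nM in the same assay. Compound 4 `COc1cc2c(Oc3ccc(NC(=O)c4cn(-c5ccccc5)nn4)cc3F)ccnc2cc1OCCCN1CCC(C)CC1` has not yet been measured. It differs from compound 2 by methyl in place of hydrogen on a saturated ring carbon. Going by the values given here, two measured steps bear on this change. The exchange of the amine ring at the end of the same chain gave a 1.3-fold lower number from compound 1 to compound 2 (0.12 log units; within the scatter), and the change at the other end of the molecule gave a 1.2-fold higher number from compound 2 to compound 3 (0.08 log units; within the scatter). Among the compounds with values here, neither step moved the number beyond the scatter, and nothing among the measured compounds points to a different outcome for an added methyl on that ring. On this basis no step beyond the scatter is expected in this assay, in either direction. Compound 4 is therefore estimated at 210 nM, with a range from 100 nM to 450 nM. That estimate means an expected step of no change at the digits printed from compound 2 to compound 4 (within the scatter) in this assay.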

Compound 4, half-maximal inhibitory concentration: 210 nM
Compound 4: the middle estimate sits on the measured number at the digits printed; measured number inside the range.
By their numbers in this assay, from the lowest: compounds 2, 4, 3 and 1 (each within the scatter of the next).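

In this assay, the added methyl on a saturated ring carbon, three ring bonds from the ring nitrogen, gives no change at the digits printed from compound 2 to compound 4 (within the scatter), so this position accepts one extra carbon without a step beyond the scatter. The earlier compounds shown here had varied this amine only by exchanging pyrrolidin-1-yl and piperidin-1-yl, and the wider exchange to 4-methylpiperidin-1-yl gives a 1.3-fold lower number from compound 1 to compound 4 (0.12 log units; within the scatter), which also stays within the scatter. Nothing available accounts for this lack of movement at the amine end of the chain.

The compounds shown leave open whether a larger group at this ring carbon, such as phenyl or hydroxymethyl, would also stay within the scatter. They also leave open how morpholin-4-yl or 4-methylpiperazin-1-yl in place of the piperidine, or a longer chain to the amine, would read in this assay.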